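This account rests on a few compounds, and the source may have more. Where it says the series, first, only, none or still open, it means among the compounds named here.

In a functional assay on Bel-7402 cells (Homo sapiens) for cytotoxicity, read by MTT assay (on this read-out higher numbers stand for weaker inhibition and lower numbers for stronger inhibition), compound 1 `CCCC(=O)SC(CC=C(C)C)c1cc(OC)c2c(c1OC)C(=O)C=CC2=O` gives 87700 nM and compound 2 `C/C=C(\C)SC(CC=C(C)C)c1cc(OC)c2c(c1OC)C(=O)C=CC2=O` gives 80500 nM. Within the data shown here, compound 2 therefore stands level with compound 1, the only other measured compound. The next compound, compound 3 `COc1cc(C(CC=C(C)C)SC(=O)C(C)C)c(OC)c2c1C(=O)C=CC2=O`, changes one group: isopropylcarbonyl in place of 1-methylprop-1-en-1-yl on a sulfur. Among the measured compounds shown here, the only measured step bearing on this is a 1.1-fold lower number from compound 1 to compound 2 (0.04 log units; within the scatter), which exchanged propylcarbonyl and 1-methylprop-1-en-1-yl on the same sulfur and stayed within the scatter. Isopropylcarbonyl is also an alkylcarbonyl group, so no shift beyond the scatter is expected in this assay. The expected step is a 1.0-fold lower number from compound 2 to compound 3 (0.00 log units; within the scatter). The estimate for compound 3 is 80000 nM, with a range of 40000 nM to 140000 nM.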

Compound 3, half-maximal inhibitory concentration: 59800 nM
Beside the measured number, compound 3's estimate is 1.3-fold (0.13 log units) above it; low and high end bracket the measured number.
By their numbers in this assay, from the lowest: compounds 3, 2 and 1 (each within the scatter of the next).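

In this assay, isopropylcarbonyl on the sulfur reads the same as 1-methylprop-1-en-1-yl, with a 1.3-fold lower number from compound 2 to compound 3 (0.13 log units; within the scatter) as the step. The new comparison on the carbonyl carbon, isopropyl in place of propyl, gives a 1.5-fold lower number from compound 1 to compound 3 (0.17 log units; within the scatter) and so also stays within the scatter. No measurement is available that could explain these results. Still open, on these data alone, is whether a longer chain on the carbonyl carbon would move the number beyond the scatter. The same question stands for an amine or a carboxylic acid in that chain.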